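The source may report more compounds than this note shows. Statements on the series, on what has been measured and on what is new or still open speak of the compounds shown alone.

Values in a functional assay on the whole organism for inhibition, with Rattus norvegicus as the target, read by paw edema (on this read-out lower numbers stand for an effect already at smaller amounts and higher numbers for an effect only at larger amounts of compound), so far
- compound 1 `O=C(O)c1cc(-c2cncs2)ccc1O` gives > 200 mg/kg (a limit, not a number)
- compound 2 `O=C(O)c1cc(-n2ccnc2)ccc1O` gives 75 mg/kg
- compound 3 `O=C(O)c1cc(-c2ncco2)ccc1O` gives 100 mg/kg

Compound 3 sits level with compound 2, the gap being a 1.3-fold higher number from compound 2 to compound 3 (0.12 log units; within the scatter) and no more. Compound 4 `O=C(O)c1cc(-c2ccno2)ccc1O` carries 1,2-oxazol-5-yl in place of 1,3-oxazol-2-yl on an aromatic carbon with the same atoms joined differently. The nearest guides are ring swaps at this same place. Both an at least 2.6-fold lower number from compound 1 to compound 2 (0.42 log units; beyond the scatter) and an at least 2.0-fold lower number from compound 1 to compound 3 (0.30 log units; that floor lies within the scatter) start from the limit of compound 1 and so give only floors. No step beyond the scatter is expected here, and the expected size is no change at the digits printed from compound 3 to compound 4 (within the scatter) at most. For compound 4 the estimated value is 100 mg/kg with an expected range of 45 mg/kg to 210 mg/kg in this read-out.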

Compound 4, dose for half-maximal effect: 110 mg/kg
Beside the measured number, compound 4's estimate is 1.1-fold (0.04 log units) below it, and the stated range covers the measured number.
By their numbers in this assay, from the lowest: compounds 2, 3 and 4 (each within the scatter of the next). At a limit, above all of these: compound 1.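

The same atoms joined differently give a 1.1-fold higher number from compound 3 to compound 4 (0.04 log units; within the scatter), so in this assay 1,2-oxazol-5-yl and 1,3-oxazol-2-yl read alike on this aromatic carbon, para to a hydroxy group. Against 1H-imidazol-1-yl the result is a 1.5-fold higher number from compound 2 to compound 4 (0.17 log units; within the scatter), which places compound 4 on one level with the other two measured rings. The step of an at least 1.8-fold lower number from compound 1 to compound 4 (0.25 log units; that floor lies within the scatter) starts from a limit and is only a floor: the limit of > 200 mg/kg in this assay, at which 1 of the 4 values shown sits.

Still open, on these data alone, is whether an amine, a pyridyl ring or a longer chain at this place would move the number beyond the scatter. Also open, as far as these compounds go, is how 1,2-oxazol-3-yl would read here.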